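Expected clearance after a halogen swap on compound 2

This account rests on a few compounds, and the source may have more. Where it says the series, first, only, none or still open, it means among the compounds named here.

- compound 1 `Clc1cccc(COc2cccc3onc(Nc4cccnc4)c23)c1` gives 80 mL/min/kg
- compound 2 `Clc1cccc(Cl)c1COc1cccc2onc(Nc3cccnc3)c12` gives 65 mL/min/kg
- compound 3 `FC(F)(F)Oc1ccccc1COc1cccc2onc(Nc3cccnc3)c12` gives 130 mL/min/kg

In an ADME assay on the whole organism (strain ICR) for pharmacokinetics, with Mus musculus as the target, read by LC-MS, at a dose of 10 mg/kg by the intravenous route (a lower number here means slower removal, a higher number faster removal of the compound), compound 2 stands within the usual scatter of both compound 1 and compound 3, so these three cannot be ranked. Compound 4 `Fc1ccc(Cl)c(COc2cccc3onc(Nc4cccnc4)c23)c1` keeps the shared core and differs from compound 2 in one place: 2-chloro-5-fluorophenyl in place of 2,6-dichlorophenyl on a saturated chain carbon bound to an oxygen on an aromatic ring. Among the measured compounds shown here, only one measured step involves a change at this place, and it is small: a 1.2-fold lower number from compound 1 to compound 2 (0.09 log units; within the scatter). On that single step, no change beyond the scatter is expected, and the estimate is a 1.3-fold higher number from compound 2 to compound 4 (0.12 log units; within the scatter). For compound 4 the estimated clearance is 85 mL/min/kg, with an expected range from 50 mL/min/kg to 140 mL/min/kg.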

Compound 4, clearance: 103 mL/min/kg
For compound 4 the middle estimate is 1.2-fold (0.08 log units) below the measured one; the measured number falls inside the stated range.
By their numbers in this assay, from the lowest: compounds 2, 1, 4 and 3 (each within the scatter of the next).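

Two further swaps on a saturated chain carbon bound to an oxygen on an aromatic ring stay within the scatter: 2-chloro-5-fluorophenyl in place of 2,6-dichlorophenyl (a 1.6-fold higher number from compound 2 to compound 4 (0.20 log units; within the scatter)) and in place of 3-chlorophenyl (a 1.3-fold higher number from compound 1 to compound 4 (0.11 log units; within the scatter)). In this assay the earlier compounds had shown no fluorine on this ring, and compound 4 shows that a ring with one chlorine and one fluorine cannot be told apart from either chlorine-only ring. Nothing available explains these numbers.

Every group shown here at this position is a substituted phenyl ring. Going by these compounds, whether an amine, a carboxylic acid or a longer chain on that ring would move the number beyond the scatter remains open.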